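Three weak aryl-triazole analogues and a dichlorophenyl newcomer

The source may report more compounds than this note shows. Statements on the series, on what has been measured and on what is new or still open speak of the compounds shown alone.

Compound 1, `N#CC1=C(N)Oc2c(c3nc4ccccc4nc3c3ccccc23)C12C(=O)N(Cc1cnnn1-c1ccc(Br)cc1)c1ccccc12`: 44300 nM
Compound 2, `COc1ccccc1-n1nncc1CN1C(=O)C2(C(C#N)=C(N)Oc3c2c2nc4ccccc4nc2c2ccccc32)c2ccccc21`: > 50000 nM
Compound 3, `Cc1ccc(-n2nncc2CN2C(=O)C3(C(C#N)=C(N)Oc4c3c3nc5ccccc5nc3c3ccccc43)c3ccccc32)cc1C`: > 50000 nM

All three measured compounds share one core and differ only in the aryl group on the triazole nitrogen. In a functional assay on A549 cells (Homo sapiens) for antiproliferative activity, read by MTT assay, with a stated time of 48 h (a higher number here means a weaker inhibitor, a lower number a stronger inhibitor), compound 1 gives 44300 nM, a weak result. For compound 2 the value > 50000 nM is a limit of this assay, not a number. For compound 3 the value > 50000 nM is likewise a limit. Compound 3 therefore stands at the weak edge of what this assay can report, as does compound 2 (the limit of > 50000 nM in this assay, at which 2 of the 3 values shown sit).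

The step to the unmeasured compound 4, `N#CC1=C(N)Oc2c(c3nc4ccccc4nc3c3ccccc23)C12C(=O)N(Cc1cnnn1-c1cc(Cl)ccc1Cl)c1ccccc12`, is 2,5-dichlorophenyl in place of 3,4-dimethylphenyl on an aromatic nitrogen. The measured steps that bear on it are an at least 1.1-fold higher number from compound 1 to compound 2 (0.05 log units; that floor lies within the scatter) and an at least 1.1-fold higher number from compound 1 to compound 3 (0.05 log units; that floor lies within the scatter), both with floors inside the scatter, while a step that the two limits leave unreadable from compound 2 to compound 3 gives no readable size. All three aryl variants sit at or near the limit, so no direction beyond the scatter is expected for the change to a dichlorophenyl.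

Compound 4 is thus expected to give about 50000 nM in this assay, between 20000 nM and 120000 nM, and the expected step of a number no higher from compound 3 to compound 4 (the limit leaves the size open) is essentially none.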

Compound 4, half-maximal inhibitory concentration: > 50000 nM
Compound 4: no number, only a limit; the forecaster's own chance of this, stated with the estimate: 60%; the middle value lies on the limit itself.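

In this assay compound 4 gives > 50000 nM, which is a limit of the assay and not a number. Going by these compounds alone, with 2,5-dichlorophenyl on the triazole nitrogen, this position has now carried a methoxy-bearing, a dimethyl-bearing and a dichloro-bearing aryl group, and all three end at the same place: the limit of > 50000 nM in this assay, at which 3 of the 4 values shown sit. The one readable step is an at least 1.1-fold higher number from compound 1 to compound 4 (0.05 log units; that floor lies within the scatter), and the steps among the three compounds held at the limit cannot be read.

The compounds shown leave open any ranking among compounds 2, 3 and 4, whose true values this assay does not report. They also leave open whether a carboxylic acid or an amine on the phenyl ring, or a longer chain in place of the ring, would give a measured number clearly away from the limit.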